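From a Dichlorophenyl Amide to an Allyl Carbamate

A few compounds are considered here, and "the series" means these few. Any claim that something is new, unique, unknown or untested is made for them only; others in the source may bear on it.

Of the compounds shown here, three sharing one core have been tested in a functional assay on WI-38 VA13 cells (Homo sapiens) for cytotoxicity; on this read-out lower numbers stand for an effect already at smaller amounts and higher numbers for an effect only at larger amounts of compound. Compound 1 `O=C(Nc1ccc2nc(NC(=O)C3CCCCC3)sc2c1)c1ccccc1Oc1ccccc1` carries a 2-phenoxyphenyl group on the carbonyl carbon, and in this assay compound 1 gives 0.1 ug/mL. Compound 2 `O=C(Nc1ccc2nc(NC(=O)C3CCCCC3)sc2c1)c1ccc(Br)cc1` has a 4-bromophenyl group in that place. For compound 2 this assay reports only a limit, > 4 ug/mL. Compound 3 `O=C(Nc1ccc2nc(NC(=O)C3CCCCC3)sc2c1)c1ccc(Cl)cc1Cl` carries a 2,4-dichlorophenyl group. For compound 3 the read-out is again a limit, > 4 ug/mL. Within the data shown here, the one measured step between compounds differing in a single place, a step that the two limits leave unreadable from compound 2 to compound 3, cannot be sized because both of its ends sit at the limit of > 4 ug/mL in this assay, at which 2 of the 3 values shown sit.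

Among the measured compounds shown here, compound 4 `C=CCOC(=O)Nc1ccc2nc(NC(=O)C3CCCCC3)sc2c1` is the next compound. allyloxy in place of 2,4-dichlorophenyl on a carbonyl carbon The only comparison with a readable number is compound 1, whose 2-phenoxyphenyl group is an aromatic group, unlike the allyloxy group entering here. Two of the three measured values sit at the limit of > 4 ug/mL in this assay, at which 2 of the 3 values shown sit, and the change moves still further from the group present in compound 1. Compound 4 is therefore expected to stay near that limit, with the step that the limit leaves unreadable from compound 3 to compound 4 expected to be small or unreadable. The estimate for compound 4 is 6 ug/mL, with a range from 2 ug/mL to 20 ug/mL.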

Compound 4, half-maximal effective concentration: 0.58 ug/mL
The estimate for compound 4 lay 10-fold (1.01 log units) above the measured number; the whole stated range lies above it.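

In this assay, among these compounds, this position proves far more tolerant of change than the earlier compounds suggested: allyloxy in place of 2,4-dichlorophenyl on the carbonyl carbon gives an at least 6.8-fold lower number from compound 3 to compound 4 (0.83 log units; beyond the scatter), and allyloxy in place of 4-bromophenyl gives an at least 6.8-fold lower number from compound 2 to compound 4 (0.83 log units; beyond the scatter). Among the compounds shown here, an aromatic ring at this place is therefore not needed for a readable number, since compound 4, which has no ring there, gives 0.58 ug/mL, whereas among the earlier compounds only compound 1 gave a readable number, at 0.1 ug/mL. Nor does a ring ensure a readable number, as compound 2 and compound 3 both carry one and give only a limit, so the two steps state minimum sizes and their true sizes stay unknown: the limit of > 4 ug/mL in this assay, at which 2 of the 4 values shown sit.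

The compounds shown leave open which part of the allyloxy group goes with the lower number, the double bond or the oxygen joined to the carbonyl carbon. A saturated propoxy group, a benzyloxy group or an allylamino group at this same place would help to separate these possibilities.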